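The source may hold more compounds than are shown below. What is called first, only, known or untested is meant among the compounds shown, and "the series" means these compounds.

Measured so far:
- compound 1, `O=C1CC(c2ccccc2)Cc2[nH]c(=O)c(C(=O)c3ccccc3)cc21`: 0%
- compound 2, `O=C1CC(c2ccccc2)Cc2[nH]c(=O)c(S(=O)(=O)c3ccccc3)cc21`: 0%
- compound 3, `CC(C)(C)C(=O)c1cc2c([nH]c1=O)CCCC2=O`: 0%

All three were tested in an assay on isolated protein for inhibition of 3',5'-cyclic-AMP phosphodiesterase 4A (Cavia porcellus), read by cAMP accumulation, tested at 1 uM; on this read-out lower numbers stand for a weaker effect and higher numbers for a stronger effect at the one concentration tested. Compound 1 gives 0%. Going by the values given here, the only single-point change among the measured compounds, phenylsulfonyl in place of benzoyl on an aromatic carbon, gives no change at the digits printed from compound 1 to compound 2 (within the scatter), so compound 2 stays at 0%. Compound 3 carries a pivaloyl-type group instead and gives 0% in this assay, level with compound 1 and compound 2 at the digits shown.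

Compound 4, `CC(C)(C)C(=O)c1cc2c([nH]c1=O)CC(c1ccccc1)CC2=O`, is not yet measured. It differs from compound 3 by phenyl in place of hydrogen on a saturated ring carbon. Among the compounds with values here, no measured step covers this exact change, but the measured compounds offer a comparison: compound 1 carries a phenyl on that saturated ring carbon and gives 0%, while compound 3 lacks it and gives 0%. Within the data shown here, nothing measured so far moved beyond the scatter, and the single step seen, from compound 1 to compound 2, was flat. The step of no change at the digits printed from compound 3 to compound 4 (within the scatter) is therefore expected to be none beyond the scatter. Compound 4 is estimated at 0% in this assay, with a range from -5% to 10%.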

Compound 4, a percentage reported as inhibition, at one concentration (the size of the read-out at that concentration, not a potency): 0%
Compound 4: middle estimate and measured number agree at the digits printed, and the stated range covers the measured number.
By their numbers in this assay, from the lowest: compounds 1, 2, 3 and 4 (each within the scatter of the next).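

In this assay, going by these compounds alone, phenyl in place of hydrogen on the saturated ring carbon gives no change at the digits printed from compound 3 to compound 4 (within the scatter), the first direct test of this position with only that one change. The group on the carbonyl carbon can also be compared directly now: tert-butyl in place of phenyl gives no change at the digits printed from compound 1 to compound 4 (within the scatter), while (tert-butyl)carbonyl in place of phenylsulfonyl on an aromatic carbon gives no change at the digits printed from compound 2 to compound 4 (within the scatter). No separate evidence accompanies these results to account for them.

Within the data shown here, with compound 4 at 0% and no step beyond the scatter, these comparisons cannot show how either position would behave in a compound with a measurable effect. As far as these compounds go, whether an amine on the saturated ring carbon, or a carboxylic acid or longer chain in place of tert-butyl, would raise the number remains open.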